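Two cores, one aryl swap: growth inhibition notes

The source may hold more compounds than are shown below. What is called first, only, known or untested is meant among the compounds shown, and "the series" means these compounds.

Compound 1 `Cc1ccc(S(=O)(=O)/C(=C/c2ccc(Br)cc2)C(=O)c2ccc(Br)cc2)cc1` is measured in a functional assay on DU-145 cells (Homo sapiens) for inhibition, read by trypan blue exclusion, with a stated time of 96 h (on this read-out lower numbers stand for stronger inhibition of growth and higher numbers for weaker inhibition of growth), where compound 1 gives 10000 nM. Compound 3 `Cc1ccc(S(=O)(=O)/C(=C/c2ccc(F)cc2F)C(=O)c2ccc(Br)cc2)cc1` is the product of the change 2,4-difluorophenyl in place of 4-bromophenyl on a double-bonded chain carbon bound to a double-bonded chain carbon on this core. In this assay compound 3 reaches only a limit of the assay, > 100000 nM. The step of an at least 10-fold higher number from compound 1 to compound 3 (1.00 log units; beyond the scatter) is therefore known only as a lower bound because of the limit of > 100000 nM in this assay, at which 1 of the 3 values shown sits.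

Compound 2 `O=C(/C(=C\c1ccc(Br)cc1)Sc1ccc(Br)cc1)c1ccc(Cl)cc1` has a different core; the difference between the two cores is not broken down here. In this assay compound 2 gives 1000 nM, the lowest of the two numbers, with compound 1 the nearest one.

Compound 4 `O=C(/C(=C\c1ccc(F)cc1F)Sc1ccc(Br)cc1)c1ccc(Cl)cc1` is not yet measured. It stands to compound 2 as compound 3 stands to compound 1, through (2,4-difluorophenyl in place of 4-bromophenyl on a double-bonded chain carbon bound to a double-bonded chain carbon), and the place is the same word for word, so it is the same change, which occurs twice among these compounds. Going by the values given here, with only one measured instance of the change, and that one ending at a limit, the transfer across cores is untested. The expectation is nonetheless that compound 4 loses potency, with a step estimated as a 15-fold higher number from compound 2 to compound 4 (1.18 log units; beyond the scatter), resting on an at least 10-fold higher number from compound 1 to compound 3 (1.00 log units; beyond the scatter). Compound 4 is estimated at 15000 nM, with a range from 3000 nM to 100000 nM, and a real chance that it too comes back only as a limit.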

Compound 4, concentration for 50% growth inhibition: 1000 nM
Compound 4: middle estimate off by 15-fold (1.18 log units), on the high side; the whole stated range lies above it.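

In this assay, 2,4-difluorophenyl in place of 4-bromophenyl gives no change at the digits printed from compound 2 to compound 4 (within the scatter), so on these two cores the change does not carry a fixed size from one to the other: the same change on two cores in this assay, an at least 10-fold higher number (1.00 log units; beyond the scatter) from compound 1 to compound 3 and no change at the digits printed (within the scatter) from compound 2 to compound 4, at least 10-fold (1.00 log units) apart, beyond the scatter of two such steps The earlier step is only a lower bound, as compound 3 stands at a limit of the assay, which leaves the true gap between the two steps open on its upper side: the limit of > 100000 nM in this assay, at which 1 of the 4 values shown sits. The result does not show which part of the cores decides the outcome, since the difference between them is not broken down, and one change on two cores gives no rule for any further core.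

Open, as far as these compounds go, is whether the lack of a step on the core of compound 2 extends to other aryl groups on the double-bonded chain carbon, or is particular to this pair of groups. Also open, from the compounds shown here alone, is whether an amine or a carboxylic acid carried on the aryl ring at that place would separate the two cores as 2,4-difluorophenyl does here, or would give similar steps on both.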